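The source may hold more compounds than are shown below. What is called first, only, known or untested is meant among the compounds shown, and "the series" means these compounds.

Measured so far:
compound 1 `NS(=O)(=O)CC(=O)NCCSc1nonc1/C(=N/O)Nc1cccc(Cl)c1` — 21 nM
compound 2 `NS(=O)(=O)NCCSc1nonc1/C(=N/O)Nc1ccc(F)c(Br)c1` — 130 nM

In an assay for inhibition of Indoleamine 2,3-dioxygenase 1 (Homo sapiens), read by fluorescence, with a stated time of 1 h (a higher number here means a weaker inhibitor, a lower number a stronger inhibitor), compound 1 gives 21 nM, the lowest of the two numbers; compound 2 gives 130 nM, a higher number beyond the usual scatter. Among the compounds with values here, no step between measured compounds differing in one place is available, so no measured single change anchors the next one. Compound 3 `N#Cc1cc(N/C(=N\O)c2nonc2SCCNC(=O)CS(N)(=O)=O)ccc1F` is not yet measured; it differs from compound 1 by 3-cyano-4-fluorophenyl in place of 3-chlorophenyl on an amine nitrogen. With nothing to rest on but compound 1 and its value, the expected step is a 1.9-fold higher number from compound 1 to compound 3 (0.28 log units; within the scatter), a small move toward a higher number, possibly still within the scatter. Compound 3 is estimated to give 40 nM in this assay, with a range of 12 nM to 150 nM.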

Compound 3, half-maximal inhibitory concentration: 150 nM
Estimate against measurement, compound 3: 3.8-fold (0.57 log units) below; the measured number falls inside the stated range.
By their numbers in this assay, from the lowest: compound 1; then compounds 2 and 3 (each within the scatter of the next).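

Working from the core of compound 1 in this assay, the group on the amine nitrogen gives the first single-place comparison in the series. Replacing 3-chlorophenyl with 3-cyano-4-fluorophenyl gives a 7.1-fold higher number from compound 1 to compound 3 (0.85 log units; beyond the scatter) and shows that inhibition in this assay responds to a change at this position. No measurement shown here bears on what lies behind this step.

The change alters several ring substituents at once, leaving the separate contributions of chlorine, nitrile and fluorine unresolved. Also open, going by these compounds, is how an unsubstituted phenyl or a 3-methoxyphenyl group would behave at this position.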